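Adding a ring hydroxy to a long-chain compound

The compounds below may be only part of what the source reports. "The series", "measured", "known", "first", "only" and "open" are said of these compounds alone.

Values in a functional assay on HEL cells (Homo sapiens) for cytotoxicity; on this read-out lower numbers stand for higher toxicity in this test and higher numbers for lower toxicity in this test:
- compound 1 `CCCCC#Cc1cc2cn([C@@H]3O[C@H](CO)[C@@H](O)[C@H]3O)c(=O)nc2o1`: > 144000 nM, a limit
- compound 2 `CCCCCCC#Cc1cc2cn([C@@H]3O[C@H](CO)[C@@H](O)[C@H]3O)c(=O)nc2o1`: > 133000 nM, a limit
- compound 3 `CCCCCCCCC#Cc1cc2cn([C@H]3C[C@H](O)[C@@H](CO)O3)c(=O)nc2o1`: 77000 nM

Among the measured compounds shown here, compound 3 gives 77000 nM, the only actual number. Compound 4 `CCCCCCCCC#Cc1cc2cn([C@@H]3O[C@H](CO)[C@@H](O)[C@H]3O)c(=O)nc2o1` differs from compound 3 by hydroxy in place of hydrogen on a saturated ring carbon. For the measured compounds named here, the one measured step, a step that the two limits leave unreadable from compound 1 to compound 2, gives no size to build on. Compound 2 carries the 3,4-dihydroxy-5-(hydroxymethyl)oxolan-2-yl group and gives > 133000 nM, which is a limit, so a move toward higher numbers in this assay is expected. The expected step is a 1.7-fold higher number from compound 3 to compound 4 (0.23 log units; within the scatter). For compound 4 the estimate is 130000 nM, with an estimated range of 60000 nM to 280000 nM.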

Compound 4, half-maximal cytotoxic concentration: 62000 nM
Beside the measured number, compound 4's estimate is 2.1-fold (0.32 log units) above it; low and high end bracket the measured number.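

In this assay, hydroxy in place of hydrogen on this saturated ring carbon stays within the scatter, with a 1.2-fold lower number from compound 3 to compound 4 (0.09 log units; within the scatter). With the 3,4-dihydroxy-5-(hydroxymethyl)oxolan-2-yl group held constant, lengthening the chain gives steps beyond the scatter, an at least 2.1-fold lower number from compound 2 to compound 4 (0.33 log units; beyond the scatter) and an at least 2.3-fold lower number from compound 1 to compound 4 (0.36 log units; beyond the scatter). Both steps start from a limit, so only their minimum size is known.

From the compounds shown here alone, whether the ring hydroxy reads the same way on the shorter chains remains open. Going by these compounds, how an amine at this ring carbon, or a longer chain, would read in this assay also remains open.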